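The compounds below may be only part of what the source reports. "The series", "measured", "known", "first", "only" and "open" are said of these compounds alone.

Measured compounds:
compound 1 `CCOC(=O)C1=C(Nc2ccccc2)S/C(=C\c2cccc(C(=O)O)c2)C1=O`, 11700 nM
compound 2 `CCOC(=O)C1=C(Nc2ccc(F)cc2)S/C(=C\c2ccc[nH]2)C1=O`, 15900 nM
compound 3 `CCOC(=O)C1=C(Nc2cccc(F)c2)S/C(=C\c2ccc[nH]2)C1=O`, 22600 nM

In a functional assay on JAR cells (Homo sapiens) for inhibition, read by MTT assay, with a stated time of 72 h (on this read-out lower numbers stand for stronger inhibition and higher numbers for weaker inhibition), compound 1 gives the lowest of the three numbers, yet compound 2 and compound 3 both sit within the usual scatter of it, so no order among them is claimed. For the measured compounds named here, the one single-point step, a 1.4-fold higher number from compound 2 to compound 3 (0.15 log units; within the scatter), concerns the amine nitrogen and not the position changed here. Compound 4 `CCOC(=O)C1=C(Nc2ccccc2)S/C(=C\c2cc3ncccc3[nH]2)C1=O` carries a group of 9 heavy atoms (7 carbon, 2 nitrogen; one five-membered aromatic ring with 1 hetero atom, one six-membered aromatic ring with 1 hetero atom) in place of a group of 9 heavy atoms (7 carbon, 2 oxygen; one six-membered aromatic ring of carbon only), on a double-bonded chain carbon bound to a double-bonded ring carbon. Compound 2 shows what a five-membered aromatic ring at that position gives; its value and that of compound 1 are alike within the scatter, so compound 4 is expected to remain near compound 1, with a 1.1-fold higher number from compound 1 to compound 4 (0.05 log units; within the scatter). Compound 4 is therefore estimated at 13000 nM, between 5000 nM and 32000 nM.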

Compound 4, half-maximal inhibitory concentration: 9600 nM
Compound 4: middle estimate off by 1.4-fold (0.13 log units), on the high side; measured number inside the range.
By their numbers in this assay, from the lowest: compounds 4, 1, 2 and 3 (each within the scatter of the next, the first and the last beyond it).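

In this assay, the group with one five-membered and one six-membered aromatic ring in place of 3-carboxyphenyl, on a double-bonded chain carbon bound to a double-bonded ring carbon, gives a 1.2-fold lower number from compound 1 to compound 4 (0.09 log units; within the scatter) and so leaves the number unmoved. This is the first comparison shown in which only this position changes, and for this pair the carboxylic acid is not needed to keep a number of this size. Nothing shown offers a measured reason for this outcome. Going by these compounds, it remains open whether a plain phenyl, or a phenyl carrying an amine, would behave alike at this place.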